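Amide in place of ester on a quinoline carboxylate core

The source may hold more compounds than are shown below. What is called first, only, known or untested is meant among the compounds shown, and "the series" means these compounds.

Compound 1, `N[C@H]1CC[C@H](Nc2c(C(=O)NCc3ccc(F)cc3)nc(N3CCCCC3)c3cccnc23)CC1`: in a functional assay on MDA-MB-435 cells (Homo sapiens) for cytotoxicity, read by MTT assay, with a stated time of 72 h (a lower number here means a stronger inhibitor, a higher number a weaker inhibitor), compound 1 gives 5000 nM.
Compound 2, `COC(=O)c1nc(Br)c2cccnc2c1N[C@H]1CC[C@H](N)CC1`: in this assay compound 2 gives > 20000 nM, which is a limit of the assay rather than a number.

Compound 2 therefore stands at the weak end of what has been measured; it sits at the limit of > 20000 nM in this assay, at which 1 of the 2 values shown sits, and no number for it is known. The account follows the change from compound 2 to compound 3, `N[C@H]1CC[C@H](Nc2c(C(=O)NCc3cccs3)nc(Br)c3cccnc23)CC1`. The change is ((thiophen-2-yl)methyl)amino in place of methoxy on a carbonyl carbon; cut one bond further out, it reads methoxycarbonyl to ((thiophen-2-yl)methyl)carbamoyl.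

No step between two measured compounds is shown, so the size of the change in this assay has to be judged from compound 1 alone, the only compound here that gives a number, 5000 nM. Compound 3 is expected to gain rather than lose in this assay, with a step of an at least 2.5-fold lower number from compound 2 to compound 3 (0.39 log units; beyond the scatter), though how far below the limit it lands is uncertain. The estimate for compound 3 in this assay is 8000 nM, between 2000 nM and 30000 nM.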

Compound 3, half-maximal inhibitory concentration: 4100 nM
Compound 3: middle estimate off by 2.0-fold (0.29 log units), on the high side, within the range that was stated.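

In this assay, within the data shown here, putting ((thiophen-2-yl)methyl)amino in place of methoxy on a carbonyl carbon gives a clear gain (an at least 4.8-fold lower number from compound 2 to compound 3 (0.68 log units; beyond the scatter)), the first step at this position that can be read at all. It shows that the ester is not needed for a measurable value at this position, as the amide compound 3 keeps the rest of compound 2 unchanged and still reads as a number, so the gain belongs to this one exchange. From the compounds shown here alone, the gain is a lower bound and its true size is unknown, because compound 2 is recorded only as a limit: the limit of > 20000 nM in this assay, at which 1 of the 3 values shown sits.

Among these compounds, compound 1 and compound 3 differ in more than one place, so no step links them, and what the thiophene ring adds over the amide itself cannot be separated from this single pair. Going by these compounds, it remains open how a carboxylic acid or a plain methylamino group on the same carbonyl carbon would read, and whether the gain would hold with an amine or a longer chain in place of the ((thiophen-2-yl)methyl)amino group.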